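A few compounds are considered here, and "the series" means these few. Any claim that something is new, unique, unknown or untested is made for them only; others in the source may bear on it.

Measured so far: compound 1 `CCCCCCC(C)Nc1ccc(NC(=O)c2cc(Cl)ccc2O)c(Cl)c1` gives 23500 nM in an ADME assay on A549 cells (Homo sapiens) for cytotoxicity, read by resazurin assay, with a stated time of 48 h; on this read-out lower numbers stand for higher toxicity in this test and higher numbers for lower toxicity in this test; compound 2 `CCCCCCCCC(C)Nc1ccc(NC(=O)c2cc(Cl)ccc2O)c(Cl)c1` gives 21900 nM; compound 3 `CN(C)c1ccc(NC(=O)c2cc(Cl)ccc2O)c(Cl)c1` gives 85100 nM.

On these numbers compound 1 stands second highest of three. Its nearest neighbour is compound 2, reached by ethyl in place of hydrogen on the chain, a step that lay within the scatter: a 1.1-fold lower number from compound 1 to compound 2 (0.03 log units; within the scatter). Its furthest neighbour is compound 3, reached by dimethylamino in place of (1-methylheptyl)amino, a modest step beyond the scatter: a 3.6-fold higher number from compound 1 to compound 3 (0.56 log units; beyond the scatter).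

Compound 4 `COc1ccc(CNc2ccc(NC(=O)c3cc(Cl)ccc3O)c(Cl)c2)cc1` has not yet been measured. It differs from compound 1 by 4-methoxybenzyl in place of 1-methylheptyl on a nitrogen on an aromatic ring. The step to compound 3 bears on this, as it likewise removes the 1-methylheptyl group; the step to compound 2 leaves that group in place and was flat. A small rise is therefore expected: a 1.4-fold higher number from compound 1 to compound 4 (0.13 log units; within the scatter). Compound 4 is estimated at 32000 nM, within 13000 nM to 80000 nM.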

Compound 4, half-maximal cytotoxic concentration: 80700 nM
Compound 4: middle estimate off by 2.5-fold (0.40 log units), on the low side; measured number outside the range, above it.
By their numbers in this assay, from the lowest: compounds 2 and 1 (each within the scatter of the next); then compounds 4 and 3 (each within the scatter of the next).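

In this assay, replacing 1-methylheptyl on the nitrogen with 4-methoxybenzyl moves the number beyond the scatter, a 3.4-fold higher number from compound 1 to compound 4 (0.54 log units; beyond the scatter), so a replacement carrying an aromatic ring and keeping the nitrogen's hydrogen also gives a rise. Compound 4 at 80700 nM and compound 3 at 85100 nM lie within the scatter of each other, so two quite different replacements end at about the same level. Nothing measured here accounts for this shift.

On these data alone, it remains open whether plain benzyl or cyclohexylmethyl on that nitrogen would match 4-methoxybenzyl, which would separate the part played by the methoxy group from that of the ring.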